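A few compounds are considered here, and "the series" means these few. Any claim that something is new, unique, unknown or untested is made for them only; others in the source may bear on it.

Compound 1, `Cc1ccc2c(c1)[n+]([O-])c(C(=O)NCc1ccccc1)c(C)[n+]2[O-]`: in an ADME assay on Vero cells (Chlorocebus sabaeus) for cytotoxicity, read by MTT assay, with a stated time of 72 h (a lower number here means a stronger inhibitor, a higher number a weaker inhibitor), compound 1 gives > 100 ug/mL, which is a limit of the assay rather than a number.
Compound 2, `Cc1c(C(=O)NCc2ccccc2)[n+]([O-])c2cc(F)ccc2[n+]1[O-]`: compound 2 gives > 100 ug/mL, again a limit.
Compound 3, `Cc1c(C(=O)NCc2ccccc2)[n+]([O-])c2cc(C(F)(F)F)ccc2[n+]1[O-]`: compound 3 gives > 100 ug/mL, again a limit.

Compound 1 therefore stands nowhere in particular on the numbers shown: it sits at the limit, and so do the two compounds measured beside it, as the limit of > 100 ug/mL in this assay, at which 3 of the 3 values shown sit, records. The three steps among them, a step that the two limits leave unreadable from compound 1 to compound 2, a step that the two limits leave unreadable from compound 1 to compound 3 and a step that the two limits leave unreadable from compound 2 to compound 3, are all left unreadable by the two limits; each of them exchanges one group on the shared core for another without moving any value off the limit.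

Compound 4, `COc1ccc(CNC(=O)c2c(C)[n+]([O-])c3ccc(C)cc3[n+]2[O-])cc1`, differs from compound 1 by methoxy in place of hydrogen on an aromatic carbon. Within the data shown here, none of the measured steps touches this part of the molecule, so none bears on it directly; what they do show is that the series, across three variations on the core, has not yet produced a readable value in this assay. On that basis compound 4 is expected to behave like compound 1, with a step that the limit leaves unreadable from compound 1 to compound 4 that is not expected to be readable. The estimate for compound 4 is 150 ug/mL, with a range from 60 ug/mL to 400 ug/mL, most probably reported again only as a limit.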

Compound 4, half-maximal inhibitory concentration: > 30 ug/mL
Compound 4 gave a limit, no number; the forecaster's own chance of this, stated with the estimate: 85%; the middle value does not contradict the limit.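

In this assay compound 4 gives > 30 ug/mL, a limit and not a number. Compound 1 gives > 100 ug/mL, also a limit, so the step between compound 1 and compound 4 cannot be read. The compounds shown leave open where any of the four would give an actual number in this assay, and whether phenyl to 4-methoxyphenyl changes it.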